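Swapping the Dihydroxyphenyl Amide for a Chloromethylphenyl

The source may hold more compounds than are shown below. What is called first, only, known or untested is meant among the compounds shown, and "the series" means these compounds.

Going by the values given here, compound 1 `Cn1c(Cc2nn(C)c(=O)c3ccccc23)nnc1SCCCCCCCC(=O)Nc1ccc(O)cc1O` is the only compound here with an actual number in an assay on isolated protein (Mus musculus) for inhibition of IL15-IL15 receptor (Homo sapiens), read by resazurin assay, with stated times of 30 min and 2.5 days; a lower number here means a stronger inhibitor, a higher number a weaker inhibitor: compound 1 gives 17000 nM. Compound 2 `CN(C(=O)CSc1nnc(Cc2nn(C)c(=O)c3ccccc23)n1C)c1ccc(Cl)cc1Cl` returns in this assay only a limit, > 30000 nM, the case noted as the limit of > 30000 nM in this assay, at which 1 of the 2 values shown sits. Compound 3 `Cc1ccc(NC(=O)CCCCCCCSc2nnc(Cc3nn(C)c(=O)c4ccccc34)n2C)c(Cl)c1` is not yet measured. It differs from compound 1 in one place (2-chloro-4-methylphenyl in place of 2,4-dihydroxyphenyl on an amide-type nitrogen). Among the compounds with values here, no step between measured compounds is available, so the direction is open. For compound 3 a modest weakening is expected, a 1.5-fold higher number from compound 1 to compound 3 (0.17 log units; within the scatter). Compound 3 is estimated at 25000 nM, within 8000 nM to 80000 nM.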

Compound 3, half-maximal inhibitory concentration: 2300 nM
The estimate for compound 3 lay 11-fold (1.04 log units) above the measured number, outside the stated range (below it).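

In this assay, the group on the amide-type nitrogen clearly matters: 2-chloro-4-methylphenyl in place of 2,4-dihydroxyphenyl gives a 7.4-fold lower number from compound 1 to compound 3 (0.87 log units; beyond the scatter) with the chain and the shared core unchanged. Compound 3 thus shows that neither hydroxyl group is required for activity here. Nothing measured here accounts for the gain.

The compounds shown leave open whether the chlorine, the methyl or the loss of the hydroxyl groups drives this step. A plain phenyl, a 2-chlorophenyl or a 4-methylphenyl on the same nitrogen would begin to separate these contributions.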